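The source may hold more compounds than are shown below. What is called first, only, known or untested is meant among the compounds shown, and "the series" means these compounds.

Series notes. Compound 1 `Cc1cnc(Nc2ccc(C#N)cc2)nc1Nc1c(F)cc(-c2cccs2)cc1F` gives 8000 nM in a toxicity assay on MT4 cells (Homo sapiens) for cytotoxicity, read by MTT assay, with a stated time of 5 days (a lower number here means that less compound is tolerated, a higher number that more compound is tolerated), and compound 2 `Cc1cnc(Nc2ccc(C#N)cc2)nc1Nc1c(F)cc(-c2cncc(C#N)c2)cc1F` gives 50000 nM. Compound 3 `Cc1cc(-c2ccnc3ccccc23)cc(C)c1Nc1ccnc(Nc2ccc(C#N)cc2)n1` gives 3500 nM, the lowest of the three numbers, so of the three it is the least tolerated. The next compound, compound 4 `Cc1cc(-c2cnc(C#N)nc2)cc(C)c1Nc1ccnc(Nc2ccc(C#N)cc2)n1`, differs from compound 3 by 2-cyanopyrimidin-5-yl in place of quinolin-4-yl on an aromatic carbon. Within the data shown here, the one measured step that bears on this exchange of an aromatic group for a nitrile-bearing heteroaryl is a 6.3-fold higher number from compound 1 to compound 2 (0.80 log units; beyond the scatter). A step of similar kind and direction is expected here, so for compound 4 the number is expected to rise by about a 4.9-fold higher number from compound 3 to compound 4 (0.69 log units; beyond the scatter). The estimate for compound 4 in this assay is 17000 nM, with a range from 7000 nM to 50000 nM.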

Compound 4, half-maximal cytotoxic concentration: 3100 nM
For compound 4 the middle estimate is 5.5-fold (0.74 log units) above the measured one, outside the stated range (below it).
By their numbers in this assay, from the lowest: compounds 4 and 3 (each within the scatter of the next); then compound 1; then compound 2.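

In this assay the exchange of quinolin-4-yl for 2-cyanopyrimidin-5-yl gives a 1.1-fold lower number from compound 3 to compound 4 (0.05 log units; within the scatter) and so separates neither compound from the other. A nitrile-bearing heteroaryl at this position therefore does not by itself go with a rise of the size of a 6.3-fold higher number from compound 1 to compound 2 (0.80 log units; beyond the scatter) on a different core and from a different leaving group. Nothing at hand accounts for the difference between these two steps.

Open, going by these compounds, is how an amine or a carboxylic acid at this position would read in this assay and whether 2-cyanopyrimidin-5-yl would give the same number on the core of compound 1.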